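Thienyl for chlorophenyl on the shared core

A few compounds are considered here, and "the series" means these few. Any claim that something is new, unique, unknown or untested is made for them only; others in the source may bear on it.

Measured so far in an assay on HEK293 cells for inhibition of Voltage-dependent N-type calcium channel subunit alpha-1B (Homo sapiens), read by fluorescence and calcium flux, with a stated time of 5 min; a higher number here means a weaker inhibitor, a lower number a stronger inhibitor:
compound 1 `COc1ccccc1-n1nc([C@@H]2CCO[C@H](C(C)C)C2)cc1-c1ccc(Cl)cc1` gives 7 nM
compound 2 `COc1ccccc1-n1nc(C2CC(C)(C)OC(C)(C)C2)cc1-c1ccc(Cl)cc1` gives 1 nM
compound 3 `CCOc1ccc(-c2cc(C3CC(C)(C)OC(C)(C)C3)nn2-c2ccccc2OC)cc1` gives 2 nM

Compound 2 sits at the bottom of the three numbers in this assay. Its gap to compound 3 is a 2.0-fold higher number from compound 2 to compound 3 (0.30 log units; within the scatter), so the two are not separated. Going by the values given here, the one real step among the three is a 7.0-fold lower number from compound 1 to compound 2 (0.85 log units; beyond the scatter), set by the change from 2-isopropyloxan-4-yl to 2,2,6,6-tetramethyloxan-4-yl on an aromatic carbon.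

Compound 4 `COc1ccccc1-n1nc(C2CC(C)(C)OC(C)(C)C2)cc1-c1csc(Cl)c1` is the next step from compound 2. The change is 5-chlorothiophen-3-yl in place of 4-chlorophenyl on an aromatic carbon.

Among the compounds with values here, only one measured step touches the same group: the change from compound 2 to compound 3 swaps ethoxy for chloro on the 4-chlorophenyl and stays within the scatter, at a 2.0-fold higher number from compound 2 to compound 3 (0.30 log units; within the scatter). Within the data shown here, no measured pair exchanges the six-membered ring itself for a five-membered one, so that part of the change is untested. The expectation for this assay is therefore a small step from compound 2 to compound 4, if any, more likely toward a higher number than a lower one, with a wide range to cover the untested ring swap: a 3.0-fold higher number from compound 2 to compound 4 (0.48 log units; beyond the scatter). Compound 4 is estimated at 3 nM, between 1 nM and 12 nM.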

Compound 4, half-maximal inhibitory concentration: 6 nM
Compound 4: the middle estimate sits 2.0-fold (0.30 log units) below what was measured; the measured number falls inside the stated range.
By their numbers in this assay, from the lowest: compounds 2 and 3 (each within the scatter of the next); then compounds 4 and 1 (each within the scatter of the next).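

In this assay, 5-chlorothiophen-3-yl in place of 4-chlorophenyl gives a 6.0-fold higher number from compound 2 to compound 4 (0.78 log units; beyond the scatter) and so lies beyond the scatter, whereas the earlier ethoxy for chloro exchange on the same phenyl ring did not. Measured against the 4-ethoxyphenyl group, the same thiophene gives a 3.0-fold higher number from compound 3 to compound 4 (0.48 log units; beyond the scatter) as a second step beyond the scatter, so this position responds to the exchange of the six-membered aromatic ring for the five-membered one in both comparisons shown. No evidence on hand accounts for these steps.

The compounds shown do not separate the effect of the ring exchange from that of the chlorine it carries, and a 5-methylthiophen-3-yl group would bear on that question. On these data alone, how a furan-3-yl or pyridin-3-yl group at this position would compare also remains open.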